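The compounds below may be only part of what the source reports. "The series", "measured", "known", "first", "only" and "open" are said of these compounds alone.

Measured so far in an ADME assay on HFF cells (Homo sapiens) for cytotoxicity, read by MTT assay, with a stated time of 72 h; a lower number here means a stronger inhibitor, a higher number a weaker inhibitor:
- compound 1, `Cc1ccc(S(=O)(=O)NCc2cn(C[C@H](O)[C@H]3OC(=O)C(OCc4ccccc4)=C3OCc3ccccc3)nn2)cc1`: 50 nM
- compound 2, `O=C1O/C(=C\Cn2cc(-c3cccc(O)c3)nn2)C(OCc2ccccc2)=C1OCc1ccccc1`: 42600 nM
- compound 3, `COc1ccccc1-c1cn(C/C=C2\OC(=O)C(OCc3ccccc3)=C2OCc2ccccc2)nn1`: > 100000 nM (a limit of the assay, not a number)

Compound 1 stands at the lowest of the two numbers given; compound 2 lies far higher, a gap well beyond the usual scatter. Compound 3 is reported only at the limit of > 100000 nM in this assay, at which 1 of the 3 values shown sits, which is a limit and not a number. Among the compounds with values here, the single step that can be measured, an at least 2.3-fold higher number from compound 2 to compound 3 (0.37 log units; beyond the scatter), concerns an aromatic substituent elsewhere on the core and says nothing about the arm that is changed next.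

Compound 4, `CCCCCCCCCCc1cn(C[C@H](O)[C@H]2OC(=O)C(OCc3ccccc3)=C2OCc2ccccc2)nn1`, differs from compound 1 in one place: nonyl in place of ((4-methylphenyl)sulfonyl)amino on a saturated chain carbon bound to an aromatic carbon. Within the data shown here, no measured step touches this arm, so the data give no direction for the change. With compound 1 at 50 nM as the only anchor, the expectation is that compound 4 stays in the same broad region, with the estimated step of a 16-fold higher number from compound 1 to compound 4 (1.20 log units; beyond the scatter) allowing room either way. The estimate for compound 4 in this assay is 800 nM, expected to fall between 60 nM and 15000 nM.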

Compound 4, half-maximal inhibitory concentration: > 100000 nM
Compound 4: a limit, no number; the forecaster's own chance of this, stated with the estimate: 5%; middle value at least 120-fold (2.09 log units) from the limit.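

In this assay, putting nonyl in place of ((4-methylphenyl)sulfonyl)amino on a saturated chain carbon bound to an aromatic carbon gives an at least 2000-fold higher number from compound 1 to compound 4 (3.30 log units; beyond the scatter), so the low number of compound 1 does not survive this single change and this arm clearly matters in the assay. From the compounds shown here alone, compound 4 gives > 100000 nM, which is a limit and not a number, and the true size of the step therefore stays unknown: the limit of > 100000 nM in this assay, at which 2 of the 4 values shown sit. The group that leaves carries a six-membered aromatic ring, a hydrogen-bond donor and hydrogen-bond acceptors, while the nonyl chain carries none of these, and one swap cannot tell which of those parts counts.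

Going by these compounds, it remains open whether an amine, a carboxylic acid or a shorter chain on this arm would keep the number as low as that of compound 1, and whether the sulfonyl part or the 4-methylphenyl ring matters more. On these data alone, it is also open whether this arm would act in the same way on the core of compound 2, which differs from compound 1 in more than one place.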